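The compounds below may be only part of what the source reports. "The series", "measured", "known", "first", "only" and "open" are said of these compounds alone.

Measured compounds:
- compound 1 `CCOC(=O)c1cnc(N2CCN(Cc3cccc(C#N)c3)CC2)nc1Oc1c(C)cc(-c2ccc(C#N)cc2)cc1C` — in an ADME assay on MT4 cells (Homo sapiens) for cytotoxicity, read by MTT assay, with a stated time of 4 days (on this read-out lower numbers stand for higher toxicity in this test and higher numbers for lower toxicity in this test), compound 1 gives > 125000 nM, a limit of the assay rather than a number.
- compound 2 `CCOC(=O)c1cnc(N2CCN(Cc3cccc(C(=O)OC)c3)CC2)nc1Oc1c(C)cc(-c2ccc(C#N)cc2)cc1C` — in this assay compound 2 gives > 125000 nM, again a limit rather than a number.
- compound 3 `CCOC(=O)c1cnc(N2CCN(Cc3cccc(C(N)=O)c3)CC2)nc1Oc1c(C)cc(-c2ccc(C#N)cc2)cc1C` — in this assay compound 3 gives 14800 nM.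

Among the measured compounds shown here, compound 3 thus stands as the only real number among the three; the other two values are limits, as the limit of > 125000 nM in this assay, at which 2 of the 3 values shown sit, shows. The unmeasured compound 4 `CCOC(=O)c1cnc(N2CCN(Cc3cc(F)cc(F)c3)CC2)nc1Oc1c(C)cc(-c2ccc(C#N)cc2)cc1C` differs from compound 3 in one place: 3,5-difluorophenyl in place of 3-carbamoylphenyl on a saturated chain carbon bound to an amine nitrogen in a ring.

For the measured compounds named here, two measured steps bear on this. Going an at least 8.4-fold lower number from compound 1 to compound 3 (0.92 log units; beyond the scatter) and going an at least 8.4-fold lower number from compound 2 to compound 3 (0.92 log units; beyond the scatter) both end at compound 3, the one compound carrying the carbamoyl group and the only one with a number. Compound 4 gives up that carbamoyl group for a 3,5-difluorophenyl. The two compounds without the carbamoyl group, compound 1 and compound 2, both sit at the limit.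

On that basis compound 4 is expected to move back toward the limit, and the expected step of a 6.1-fold higher number from compound 3 to compound 4 (0.78 log units; beyond the scatter) is therefore upward in number, beyond the scatter. Compound 4 is expected to give about 90000 nM, with a range from 25000 nM to 125000 nM, and a fair chance that only a limit is reported.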

Compound 4, half-maximal cytotoxic concentration: > 125000 nM
Compound 4 gave a limit, no number (the forecaster's own chance of this, stated with the estimate: 55%); middle value at least 1.3-fold (0.14 log units) away from the limit.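

On the saturated chain carbon bound to an amine nitrogen in a ring, putting 3,5-difluorophenyl in place of 3-carbamoylphenyl gives an at least 8.4-fold higher number from compound 3 to compound 4 (0.92 log units; beyond the scatter), so in this assay the lower number of compound 3 does not carry over to a ring with two fluorines and no carbamoyl group. The earlier comparisons shown here at this place covered only a nitrile and a methyl ester, whereas compound 4 adds a ring with no hydrogen-bond donors or acceptors, and compound 3 is still the only one of the four with a real number. The steps from compound 1 and from compound 2 to compound 4 cannot be read, because all three compounds end at a limit of the assay rather than a number: the limit of > 125000 nM in this assay, at which 3 of the 4 values shown sit.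

From the compounds shown here alone, how far the true value of compound 4 lies from that of compound 3 remains open, since only a minimum size is known for the step. Going by these compounds, it is also open whether the number seen for compound 3 is special to the carbamoyl group or would also appear with a carboxylic acid, an aminomethyl group or an N-methylcarbamoyl group on the same ring.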